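The source may report more compounds than this note shows. Statements on the series, on what has been measured and on what is new or still open speak of the compounds shown alone.

Within the data shown here, in a functional assay on MDA-MB-231 cells (Homo sapiens) for antiproliferative activity, read by MTT assay, with a stated time of 72 h (on this read-out lower numbers stand for stronger inhibition and higher numbers for weaker inhibition), compound 1 `O=C(Nc1cccc(-c2nc(-c3ccc(NC(=O)c4cccnc4)cc3Cl)no2)c1)c1ccccc1` gives 12800 nM, which is the only exact number available so far. Compound 2 `NS(=O)(=O)c1ccc(S(=O)(=O)Nc2cccc(-c3nc(-c4ccc(NC(=O)c5cccnc5)cc4Cl)no3)c2)cc1` gives > 10000 nM, and this is a limit of the assay, not a number. That leaves compound 1 as the sole firm reference point, with the limit of > 10000 nM in this assay, at which 1 of the 2 values shown sits, as the other piece of evidence.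

The next compound to be tested is compound 3 `Cc1ccc(S(=O)(=O)Nc2cccc(-c3nc(-c4ccc(NC(=O)c5cccnc5)cc4Cl)no3)c2)cc1`. It keeps the shared core of compound 1 and differs in a single place: (4-methylphenyl)sulfonyl in place of benzoyl on a nitrogen on an aromatic ring. In words, (4-methylphenyl)sulfonyl stands in place of benzoyl on a nitrogen on an aromatic ring. Both groups carry one six-membered aromatic ring of carbon only, so the swap mainly replaces the link that joins this ring to the nitrogen.

Among the measured compounds shown here, no measured pair shows what this swap does in this assay, so no change beyond the usual scatter is expected, in either direction. The expectation starts from compound 1 at 12800 nM. The expected step is a 1.0-fold higher number from compound 1 to compound 3 (0.01 log units; within the scatter). For compound 3, the estimated value is 13000 nM, with an expected range from 5000 nM to 40000 nM.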

Compound 3, half-maximal inhibitory concentration: > 10000 nM
Compound 3 gave a limit, no number (the forecaster's own chance of this, stated with the estimate: 35%); the middle value does not contradict the limit.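

In this assay compound 3 gives > 10000 nM, which is a limit of the assay and not a number. No step from compound 1 or compound 2 to compound 3 can be read, because the comparison rests on limits: the limit of > 10000 nM in this assay, at which 2 of the 3 values shown sit.

The compounds shown leave open how much (4-methylphenyl)sulfonyl in place of benzoyl changes the value in this assay.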